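The source may report more compounds than this note shows. Statements on the series, on what has been measured and on what is new or still open speak of the compounds shown alone.

Notes on the series, step from compound 2 to compound 3.

Among the measured compounds shown here, compound 2 `CC(C)Cc1ccc(-c2nc(-c3ccc([C@@H]4CC[C@@H](C(=O)O)N4)cc3)no2)cc1` is the lower of the two numbers so far in an assay on CHO cells for displacement of a labelled ligand from sphingosine 1-phosphate receptor 5 (Homo sapiens); on this read-out lower numbers stand for stronger inhibition and higher numbers for weaker inhibition: compound 2 gives 180 nM, while compound 1 `CC(C)Cc1ccc(-c2nc(-c3ccc([C@H]4CC[C@@H](C(=O)O)N4)cc3)no2)cc1` gives 1280 nM. For the measured compounds named here, the one measured step, a 7.1-fold lower number from compound 1 to compound 2 (0.85 log units; beyond the scatter), rests on the fact that compounds 1 and 2 differ only in the configuration as drawn and so speaks only to configuration.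

Compound 3 `CC(C)Cc1ccc(-c2nc(-c3ccc([C@H]4CC[C@@H](CC(=O)O)N4)cc3)no2)cc1` carries 5-(carboxymethyl)pyrrolidin-2-yl in place of 5-carboxypyrrolidin-2-yl on an aromatic carbon; in words, 5-(carboxymethyl)pyrrolidin-2-yl in place of 5-carboxypyrrolidin-2-yl on an aromatic carbon. Going by the values given here, the configuration as drawn is kept, so the measured step from compound 1 to compound 2 does not bear on this change; no measured pair separates a carboxy from a carboxymethyl group here. Extending the acid by one carbon is therefore judged without precedent in the series, and a step in either direction is possible.

The working estimate for compound 3 in this assay is 400 nM, range 90 nM to 2000 nM, which is an expected step of a 2.2-fold higher number from compound 2 to compound 3 (0.35 log units; beyond the scatter).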

Compound 3, half-maximal inhibitory concentration: 200 nM
Estimate against measurement, compound 3: 2.0-fold (0.30 log units) above; the measured number falls inside the stated range.
By their numbers in this assay, from the lowest: compounds 2 and 3 (each within the scatter of the next); then compound 1.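

In this assay, among the compounds shown here, the first change to the acid chain with the drawn configuration held fixed gives a 6.4-fold lower number from compound 1 to compound 3 (0.81 log units; beyond the scatter), so this position tolerates carboxymethyl in place of carboxy and the number of compound 1 can be lowered without changing that configuration. For the compounds shown here, until this point, the only measured step spoke to configuration alone, because of this: the fact that compounds 1 and 2 differ only in the configuration as drawn. Compound 3 differs from compound 2 in both the chain and the drawn configuration, and the listed step of a 1.1-fold higher number from compound 2 to compound 3 (0.05 log units; within the scatter) places the two level, so either change alone reaches that level from compound 1.

Open, on these data alone, is whether carboxymethyl with the drawn configuration of compound 2 would move the number further. Also open, as far as these compounds go, is how a longer carboxyethyl chain, or a primary amide in place of the carboxylic acid, would read.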